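Nitro for Chloro on Two Thiourea Sulfonamide Cores

A few compounds are considered here, and "the series" means these few. Any claim that something is new, unique, unknown or untested is made for them only; others in the source may bear on it.

Compound 1 `O=S(=O)(NCCNC(=S)Nc1cccc(Cl)c1)c1ccc(-c2ccccc2OCc2cccc(O)c2)s1` and compound 2 `O=[N+]([O-])c1cccc(NC(=S)NCCNS(=O)(=O)c2ccc(-c3ccccc3OCc3cccc(O)c3)s2)c1` share one core. In an ADME assay on HEK-293T cells (Homo sapiens) for cytotoxicity, read by CCK-8 assay, with a stated time of 48 h (on this read-out higher numbers stand for weaker inhibition and lower numbers for stronger inhibition), compound 1 gives 17400 nM, and compound 2 gives 13800 nM. The change between them, (nitro in place of chloro on an aromatic carbon), made a step of a 1.3-fold lower number from compound 1 to compound 2 (0.10 log units; within the scatter). Compound 3 `O=S(=O)(c1sccc1-c1ccccc1Oc1ccc(O)c(O)c1)N1CCN(C(=S)Nc2ccc(Cl)cc2)CC1` is built on a different core; the difference between the two cores is not broken down here. In this assay compound 3 reaches only a limit, > 50000 nM, namely (the limit of > 50000 nM in this assay, at which 1 of the 3 values shown sits). Compound 4 `O=[N+]([O-])c1ccc(NC(=S)N2CCN(S(=O)(=O)c3sccc3-c3ccccc3Oc3ccc(O)c(O)c3)CC2)cc1` differs from compound 3 by nitro in place of chloro on an aromatic carbon. This is the same kind of change as before, with the group now para to a large group rather than meta to a large group. The step that the limit leaves unreadable from compound 3 to compound 4 is expected to be small, resting on a 1.3-fold lower number from compound 1 to compound 2 (0.10 log units; within the scatter). Compound 4 is therefore expected to come out near 60000 nM, between 25000 nM and 150000 nM.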

Compound 4, half-maximal inhibitory concentration: > 20000 nM
Compound 4: no number, only a limit; the forecaster's own chance of this, stated with the estimate: 70%; the middle value does not contradict the limit.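

Compound 3 and compound 4 each stand only as a limit in this assay, and the step between them cannot be read. As far as these compounds go, whether nitro in place of chloro shifts the number on the core of compound 3 stays open.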